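This account rests on a few compounds, and the source may have more. Where it says the series, first, only, none or still open, it means among the compounds named here.

Compound 3 `CCCCCCCCCCCCCCC(=O)Nc1c(OC)cc(OC)cc1OC` gives the lowest number of the three measured compounds in an assay on microsomes from intestine for inhibition of acyl-CoA:cholesterol acyltransferase (Oryctolagus cuniculus) (a lower number here means a stronger inhibitor, a higher number a weaker inhibitor), at 65 nM. Compound 2 `CCCCCCCCCCCCCC(=O)Nc1c(OC)cc(OC)cc1OC` gives 190 nM in this assay, and compound 1 `CCCCCCCC/C=C/CCCCCCCC(=O)Nc1cc(C(=O)OC)ccc1OC` gives 430 nM. Compound 4 `CCCCCCCCCCCCCCCC(=O)Nc1c(OC)cc(OC)cc1OC` differs from compound 3 by methyl in place of hydrogen on a saturated chain carbon, ten or more bonds along the chain from a carbonyl carbon. Going by the values given here, one measured step bears on this change: a 2.9-fold lower number from compound 2 to compound 3 (0.47 log units; beyond the scatter), which extended the same saturated chain by a methyl and moved the number modestly downward. Compound 4 repeats that extension one carbon further out, so a further downward step of similar or somewhat smaller size is expected, a 1.6-fold lower number from compound 3 to compound 4 (0.21 log units; within the scatter). Compound 4 is therefore estimated to give about 40 nM in this assay, with a likely range from 18 nM to 100 nM.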

Compound 4, half-maximal inhibitory concentration: 54 nM
Compound 4: the middle estimate sits 1.4-fold (0.13 log units) below what was measured, within the range that was stated.
By their numbers in this assay, from the lowest: compounds 4 and 3 (each within the scatter of the next); then compound 2; then compound 1.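

One more methyl at this place on the chain gives a 1.2-fold lower number from compound 3 to compound 4 (0.08 log units; within the scatter) in this assay, so the earlier modest step does not clearly repeat here. Taken together as ethyl in place of hydrogen, the change gives a 3.5-fold lower number from compound 2 to compound 4 (0.55 log units; beyond the scatter), a shift that can be read with confidence. No evidence is available to explain these results. Still open, going by these compounds, is whether a longer chain than that of compound 4 would keep this level in this assay or lose it, and what a carboxylic acid or an amine at this place would do.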